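The source may report more compounds than this note shows. Statements on the series, on what has been measured and on what is new or still open speak of the compounds shown alone.

Three compounds in the series carry measurements in a functional assay on MKN-74 cells (Homo sapiens) for antiproliferative activity, with a stated time of 24 h; on this read-out higher numbers stand for weaker inhibition and lower numbers for stronger inhibition. Compound 1 `NC(=O)c1c(NC(=O)c2ccc(C(F)(F)F)cc2)sc2c1CCN(Cc1ccccc1F)C2` gives 26900 nM; compound 2 `NC(=O)c1c(NC(=O)c2ccccc2I)sc2c1CCN(C(=S)Nc1ccccc1Cl)C2` gives 17500 nM; compound 3 `NC(=O)c1c(NC(=O)c2ccccc2C(F)(F)F)sc2c1CCN(C(=S)Nc1ccccc1Cl)C2` gives 21900 nM. Compound 3 stands second highest of the three numbers, with compound 1 nearest and compound 2 furthest, both within the scatter. Within the data shown here, the only measured step, a 1.3-fold higher number from compound 2 to compound 3 (0.10 log units; within the scatter), exchanges iodo for trifluoromethyl and stays within the scatter. Compound 4 `NC(=O)c1c(NC(=O)c2ccc(C(F)(F)F)cc2)sc2c1CCN(C(=S)Nc1ccccc1Cl)C2` differs from compound 3 by 4-(trifluoromethyl)phenyl in place of 2-(trifluoromethyl)phenyl on a carbonyl carbon. Among the measured compounds shown here, no measured step relates a 2-(trifluoromethyl)phenyl to a 4-(trifluoromethyl)phenyl; compound 1, which carries the 4-(trifluoromethyl)phenyl, sits within the scatter of compound 3. The expected step is therefore a 1.1-fold higher number from compound 3 to compound 4 (0.04 log units; within the scatter), nothing beyond the scatter. Compound 4 is expected near 24000 nM, within 12000 nM to 48000 nM.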

Compound 4, half-maximal inhibitory concentration: 16400 nM
Compound 4: the middle estimate sits 1.5-fold (0.17 log units) above what was measured, and the stated range covers the measured number.
By their numbers in this assay, from the lowest: compounds 4, 2, 3 and 1 (each within the scatter of the next).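

In this assay, 4-(trifluoromethyl)phenyl in place of 2-(trifluoromethyl)phenyl on the carbonyl carbon gives a 1.3-fold lower number from compound 3 to compound 4 (0.13 log units; within the scatter), so this assay does not tell the two groups apart. 4-(Trifluoromethyl)phenyl in place of 2-iodophenyl gives a 1.1-fold lower number from compound 2 to compound 4 (0.03 log units; within the scatter), and the change on the amine nitrogen in a ring gives a 1.6-fold lower number from compound 1 to compound 4 (0.21 log units; within the scatter), so neither site yet shows a readable difference. No independent measurement on hand bears on these results. From the compounds shown here alone, whether an amine or a carboxylic acid in place of trifluoromethyl on this phenyl would move the number beyond the scatter remains open.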